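A few compounds are considered here, and "the series" means these few. Any claim that something is new, unique, unknown or untested is made for them only; others in the source may bear on it.

Measured compounds in a functional assay on MIA PaCa-2 cells (Homo sapiens) for inhibition, read by MTT assay, with a stated time of 3 days; a higher number here means a weaker inhibitor, a lower number a stronger inhibitor:
compound 1 `CC(C)c1noc(N2CCN(C(=O)[C@@H]3CCCN(S(=O)(=O)c4ccc(S(=O)(=O)C5CCC5)cc4)C3)CC2)n1` gives 20 nM;
compound 2 `CC(C)c1noc(N2CCN(C(=O)[C@@H]3CCCN(S(=O)(=O)c4ccc(S(=O)(=O)C(C)C)cc4)C3)CC2)n1` gives 30 nM;
compound 3 `CCN(CC)S(=O)(=O)c1ccc(S(=O)(=O)N2CCC[C@@H](C(=O)N3CCN(c4nc(C(C)C)no4)CC3)C2)cc1` gives 30 nM.

Compound 3 stands level with compound 2 at the digits shown, the two together the highest numbers of the three; compound 1 is the furthest, and a 1.5-fold higher number from compound 1 to compound 3 (0.18 log units; within the scatter).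

Compound 4 `CC(C)c1noc(N2CCN(C(=O)[C@@H]3CCCN(S(=O)(=O)c4ccc(S(=O)(=O)NC5CCC5)cc4)C3)CC2)n1` differs from compound 3 by cyclobutylamino in place of diethylamino on a sulfonyl sulfur. Among the compounds with values here, the steps that bear on this position are a 1.5-fold higher number from compound 1 to compound 2 (0.18 log units; within the scatter), a 1.5-fold higher number from compound 1 to compound 3 (0.18 log units; within the scatter) and no change at the digits printed from compound 2 to compound 3 (within the scatter); all three exchanges at this sulfonyl sulfur sit within the scatter. Within the data shown here, no measured step covers a group with a hydrogen-bond donor at this position, so the expectation rests on the small spread already seen. Compound 4 is therefore expected to give 30 nM (range 12 nM to 80 nM), which means an estimated no change at the digits printed from compound 3 to compound 4 (within the scatter), nothing beyond the scatter.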

Compound 4, half-maximal inhibitory concentration: 200 nM
Compound 4: the middle estimate sits 6.7-fold (0.82 log units) below what was measured; the whole stated range lies below it.
By their numbers in this assay, from the lowest: compounds 1, 2 and 3 (each within the scatter of the next); then compound 4.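

In this assay, within the data shown here, cyclobutylamino is the first group on this sulfonyl sulfur to give a step beyond the scatter: a 6.7-fold higher number from compound 3 to compound 4 (0.82 log units; beyond the scatter), a 6.7-fold higher number from compound 2 to compound 4 (0.82 log units; beyond the scatter) and a 10-fold higher number from compound 1 to compound 4 (1.00 log units; beyond the scatter). Compound 1 carries a cyclobutyl ring too, so the ring alone does not go with the higher number; among these four compounds, only compound 4 has a hydrogen-bond donor on this group. No measurement here accounts for the loss.

Open, as far as these compounds go, is whether N-methyl-N-cyclobutylamino, which keeps the ring but lacks the nitrogen hydrogen, returns to the level of compound 1. Also open, from the compounds shown here alone, is whether an open-chain ethylamino group behaves like compound 4.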